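4-Fluorobenzyl to 4-nitrobenzyl: notes on the series

A few compounds are considered here, and "the series" means these few. Any claim that something is new, unique, unknown or untested is made for them only; others in the source may bear on it.

- compound 1 `COc1cccc(C(=O)Oc2ccc3c(=O)c(-c4cc(OC)c(OC)cc4OC)coc3c2)c1`: > 10000 nM (a limit)
- compound 2 `COc1cc(OC)c(-c2coc3cc(OCC(=O)c4cccc(C(F)(F)F)c4)ccc3c2=O)cc1OC`: > 10000 nM (a limit)
- compound 3 `COc1cc(OC)c(-c2coc3cc(OCc4ccc(F)cc4)ccc3c2=O)cc1OC`: 1120 nM

Among the compounds with values here, in a functional assay on B16 cells (Mus musculus) for antiproliferative activity, read by MTT assay, with a stated time of 24 h (on this read-out lower numbers stand for stronger inhibition and higher numbers for weaker inhibition), compound 3 gives 1120 nM, the only true number in the set. Compound 1 and compound 2 give no number, only (the limit of > 10000 nM in this assay, at which 2 of the 3 values shown sit).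

Compound 4 `COc1cc(OC)c(-c2coc3cc(OCc4ccc([N+](=O)[O-])cc4)ccc3c2=O)cc1OC` keeps everything in compound 3 except one group: nitro in place of fluoro on an aromatic carbon, para to a large group (nitro in place of fluoro on an aromatic carbon).

Within the data shown here, two measured steps bear on this only indirectly: an at least 8.9-fold lower number from compound 1 to compound 3 (0.95 log units; beyond the scatter) and an at least 8.9-fold lower number from compound 2 to compound 3 (0.95 log units; beyond the scatter). Both are beyond the scatter, but each replaces the whole group on the oxygen and starts from a limit. Among the measured compounds shown here, no measured step changes only the group para to the large group, and here the benzyl stays in place. No step beyond the scatter is therefore expected in this assay, with a slight lean towards a higher number. The expected change is a 1.3-fold higher number from compound 3 to compound 4 (0.13 log units; within the scatter). For compound 4 the estimated value is 1500 nM, with an expected range of 400 nM to 6000 nM.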

Compound 4, half-maximal inhibitory concentration: > 10000 nM
Compound 4: only a limit was reported; the forecaster's own chance of this, stated with the estimate: 15%; at least 6.6-fold (0.82 log units) between middle value and limit.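

In this assay, a change confined to the aromatic carbon para to a large group now has a measured step of its own, with nitro in place of fluoro: an at least 8.9-fold higher number from compound 3 to compound 4 (0.95 log units; beyond the scatter). Within the data shown here, the earlier steps replaced the whole group on the oxygen, whereas here the benzyl stays in place, so the exchange of this one group is enough to separate compound 3, the only true number, from the limit. The value of compound 4 is a limit and not a number, which places it with compound 1 and compound 2: the limit of > 10000 nM in this assay, at which 3 of the 4 values shown sit.

On these data alone, the steps from compound 1 and from compound 2 to compound 4 cannot be read, and the full size of the step from fluoro to nitro stays open. Also open, as far as these compounds go, is what a plain hydrogen, a chlorine, a methoxy group or an amine would give at this same carbon.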